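The source may report more compounds than this note shows. Statements on the series, on what has been measured and on what is new or still open speak of the compounds shown alone.

Compound 1 `CCOC(=O)c1c(-c2cccc(OC(F)(F)F)c2)[nH]c2cc(OC)ccc2c1=O`, in an ADME assay on Raji cells (Homo sapiens) for cytotoxicity, read by luminescence, with a stated time of 72 h; a higher number here means that more compound is needed for the effect, a lower number that less compound is needed: > 21500 nM, a limit of the assay.
Compound 2 `CCOC(=O)c1c(-c2cccc(N(C)C)c2)[nH]c2cc(OC)ccc2c1=O`, in this assay: > 21500 nM, likewise a limit.

Going by the values given here, compound 1 therefore stands only at a limit in this assay, as does the one other value shown (the limit of > 21500 nM in this assay, at which 2 of the 2 values shown sit). The step that the two limits leave unreadable from compound 1 to compound 2 is unreadable because of the limit of > 21500 nM in this assay, at which 2 of the 2 values shown sit. Compound 3 `CCOC(=O)c1c(-c2cccc(CO)c2)[nH]c2cc(OC)ccc2c1=O` has not been measured; it differs from compound 1 by hydroxymethyl in place of trifluoromethoxy on an aromatic carbon. No readable step bears on this change, so no direction can be drawn for it. Compound 3 is expected to give about 30000 nM in this assay, between 8000 nM and 100000 nM. The expected step is a step that the limit leaves unreadable from compound 1 to compound 3.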

Compound 3, half-maximal effective concentration: > 21500 nM
Compound 3 gave a limit, no number; the forecaster's own chance of this, stated with the estimate: 75%; the middle value does not contradict the limit.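

No step between compound 1, compound 2 and compound 3 can be read in this assay, because all three stop at a limit of the assay: the limit of > 21500 nM in this assay, at which 3 of the 3 values shown sit.

Going by these compounds, what remains open is how far compound 1, compound 2 and compound 3 actually differ in this assay, if they differ at all.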